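This account rests on a few compounds, and the source may have more. Where it says the series, first, only, none or still open, it means among the compounds named here.

Measured compounds:
- compound 1, `COc1cc2nc(/C=C/c3cccc(F)c3)nc(N3CCC(CCNS(N)(=O)=O)CC3)c2cc1OC`: 14% in an assay on cells for inhibition of Ectonucleotide pyrophosphatase/phosphodiesterase family member 1 (Homo sapiens), with a stated time of 60 min, tested at 1 uM; a lower number here means less inhibition, a higher number more inhibition at the concentration tested (going by the name of the read-out)
- compound 2, `COc1cc2ncnc(N3CCC(CCNS(C)(=O)=O)CC3)c2cc1OC`: 12%

Both readings sit near the bottom of the scale for this series. Compound 2 gives the lowest of the two numbers shown, yet the gap to compound 1 is within the usual scatter, so the two cannot be told apart on this assay. For the measured compounds named here, no pair of measured compounds differs in one place only, so no step has been measured.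

Compound 3, `COc1cc2ncnc(N3CCC(CCN)CC3)c2cc1OC`, is the unmeasured compound. Its difference from compound 2 is hydrogen in place of methylsulfonyl on an amine nitrogen. Since both measured compounds lie close to the floor of the read-out, the expectation for this change is a step of no size beyond the scatter, in no fixed direction. The expected step is no change at the digits printed from compound 2 to compound 3 (within the scatter). For compound 3 the estimate in this assay is 12%, within a range from 0% to 28%.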

Compound 3, a percentage reported as inhibition, at one concentration (the size of the read-out at that concentration, not a potency): 45%
Compound 3: middle estimate off by 33 percentage points, on the low side; the measured number lies above the stated range.
By their numbers in this assay, from the lowest: compounds 2 and 1 (each within the scatter of the next); then compound 3.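

In this assay, for the compounds shown here, the change from 2-(methanesulfonamido)ethyl to 2-aminoethyl gives a large step, a number 33 percentage points higher from compound 2 to compound 3 (beyond the scatter), the first measured step. The substituent on this amine nitrogen therefore matters to the read-out: with the shared core and the chain held constant, hydrogen in place of methylsulfonyl raises inhibition at the concentration tested, which the two earlier readings, within the scatter of each other, could not show. Nothing measured here accounts for the step.

On these data alone, it remains open whether the rise depends on the free amine itself or only on the loss of methylsulfonyl, a question that an acetyl group or a methyl group on the same nitrogen would address. Also open, as far as these compounds go, are a longer chain in place of the ethyl link and whether a free amine would behave the same way on the core of compound 1.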